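This account rests on a few compounds, and the source may have more. Where it says the series, first, only, none or still open, it means among the compounds named here.

Compound 1 `CC(=O)OCCC(=O)O[C@H](CC=C(C)C)C1=CC(=O)c2c(O)ccc(O)c2C1=O` gives 17300 nM in a functional assay on HeLa cells (Homo sapiens) for cytotoxicity, read by MTT assay; a lower number here means a stronger inhibitor, a higher number a weaker inhibitor.
Compound 2 `CCC(C)(O)CC(=O)O[C@H](CC=C(C)C)C1=CC(=O)c2c(O)ccc(O)c2C1=O` gives 25200 nM in this assay.
Compound 3 `CC(C)=CC[C@@H](OC(=O)CCO)C1=CC(=O)c2c(O)ccc(O)c2C1=O` gives 67600 nM in this assay.

Compound 3 carries the highest number of the three: the steps of a 2.7-fold higher number from compound 2 to compound 3 (0.43 log units; beyond the scatter) and a 3.9-fold higher number from compound 1 to compound 3 (0.59 log units; beyond the scatter) both lie beyond the scatter. Compound 4 `CC(C)=CC[C@@H](OC(=O)CC(O)c1ccccc1)C1=CC(=O)c2c(O)ccc(O)c2C1=O` is not yet measured. It differs from compound 3 by phenyl in place of hydrogen on a saturated chain carbon bound to an oxygen on a saturated carbon and a saturated chain carbon.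

Among the measured compounds shown here, two measured steps bear on this change, since both alter the same chain end. In this assay the step of a 2.7-fold higher number from compound 2 to compound 3 (0.43 log units; beyond the scatter) shows that trimming the 1-hydroxy-1-methylpropyl to hydroxymethyl raised the number modestly, and a 3.9-fold higher number from compound 1 to compound 3 (0.59 log units; beyond the scatter) shows that removing the acetyl from the oxygen also raised it modestly. Adding a phenyl next to the hydroxyl therefore is expected to lower the number by a modest step in this assay, about a 2.7-fold lower number from compound 3 to compound 4 (0.43 log units; beyond the scatter). Compound 4 is estimated at 25000 nM, with a range from 10000 nM to 70000 nM.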

Compound 4, half-maximal inhibitory concentration: 44500 nM
The estimate for compound 4 lay 1.8-fold (0.25 log units) below the measured number; the measured number falls inside the stated range.
By their numbers in this assay, from the lowest: compounds 1, 2, 4 and 3 (each within the scatter of the next, the first and the last beyond it).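

In this assay, phenyl in place of hydrogen on this saturated chain carbon gives a 1.5-fold lower number from compound 3 to compound 4 (0.18 log units; within the scatter) and so cannot be told from the scatter, which shows that this chain carbon bears the phenyl without a clear shift in the number. The hydroxy(phenyl)methyl group likewise stays within the scatter of the 1-hydroxy-1-methylpropyl group at a 1.8-fold higher number from compound 2 to compound 4 (0.25 log units; within the scatter) and only the comparison with the acetoxymethyl group, at a 2.6-fold higher number from compound 1 to compound 4 (0.41 log units; beyond the scatter) and modest in size, lies beyond it. Nothing at hand gives a reason for these steps.

Open, going by these compounds, is whether an amine in place of the hydroxyl on this chain carbon, or a longer chain in place of the phenyl, would carry the number beyond the scatter of compound 3. Also open, on these data alone, is whether an acetyl on the hydroxyl of compound 4 would lower its number.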